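Removing the hydroxy from compound 2

This account rests on a few compounds, and the source may have more. Where it says the series, first, only, none or still open, it means among the compounds named here.

Of the compounds shown here, two have been measured in a functional assay on the whole organism with Mus musculus as the target, at a dose of 100 mg/kg by the intraperitoneal route; on this read-out higher numbers stand for more inhibition at the one dose given (going by the name of the read-out) and lower numbers for less inhibition. Compound 1 `CN(C)C(=O)/C=C1\CCc2ccc(F)cc21` gives 100%, and compound 2 `O=C(/C=C1\CCc2ccc(F)cc21)NCCO` gives 50%, the lowest of the two numbers. For the measured compounds named here, the only measured step is a number 50 percentage points lower from compound 1 to compound 2 (beyond the scatter), which lies beyond the scatter. Compound 3 `CCNC(=O)/C=C1\CCc2ccc(F)cc21` differs from compound 2 by hydrogen in place of hydroxy on a saturated chain carbon, two bonds along the chain from an amide-type nitrogen. Going by the values given here, no measured step changes a hydroxy on its own, and the step from compound 1 to compound 2 altered the amide substitution as a whole, so it bears on this change only indirectly: compound 3 lies, in structure, partway back toward compound 1. The change from compound 2 to compound 3 is therefore expected to be upward, with a number 20 percentage points higher from compound 2 to compound 3 (beyond the scatter) as a moderate step. Compound 3 is estimated at 70%, with a range from 45% to 95%.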

Compound 3, a percentage reported as inhibition, in the whole organism at one dose (the size of the read-out at that dose, not a potency): 100%
Compound 3: the middle estimate sits 30 percentage points below what was measured, and the stated range ends below it.
By their numbers in this assay, from the lowest: compound 2; then compounds 1 and 3 (each within the scatter of the next).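

In this assay, the hydroxy on this saturated chain carbon, two bonds along the chain from an amide-type nitrogen, is now changed on its own, and hydrogen in its place gives a number 50 percentage points higher from compound 2 to compound 3 (beyond the scatter). Ethylamino in place of dimethylamino on a carbonyl carbon gives no change at the digits printed from compound 1 to compound 3 (within the scatter), so among these three compounds the lower number goes with the hydroxy, not with the exchange of dimethylamino for an amino group bearing one chain. Nothing given here explains why the hydroxy has this effect on the read-out.

The compounds shown leave open whether a methoxy, an amine or a carboxylic acid at this chain position would behave like the hydroxy or like hydrogen. They also leave open how a longer chain in place of ethyl would read in this assay.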